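The source may hold more compounds than are shown below. What is called first, only, known or untested is meant among the compounds shown, and "the series" means these compounds.

Measured so far in a functional assay on MCF-10A cells (Homo sapiens) for antiproliferative activity, with a stated time of 48 h; on this read-out higher numbers stand for an effect only at larger amounts of compound and lower numbers for an effect already at smaller amounts:
- compound 1 `COc1ccc2nc(C)cc(NCc3ccc(F)cc3C(F)(F)F)c2c1` gives 4200 nM
- compound 2 `COc1ccc2nc(C)cc(NCc3cccc(OC(F)F)c3)c2c1` gives 14300 nM
- compound 3 `COc1ccc2nc(C)cc(NCc3ccc(F)c(OC)c3)c2c1` gives 12900 nM

Compound 2 (14300 nM) carries the highest number of the three, but compound 3 (12900 nM) lies within the scatter of it. Only compound 1 (4200 nM) stands lower than compound 2 by more than the scatter.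

Compound 4 `COc1ccc2nc(C)cc(NCc3cccc(CO)c3)c2c1` is the next to be read. It has hydroxymethyl in place of difluoromethoxy on an aromatic carbon, meta to a large group (hydroxymethyl in place of difluoromethoxy on an aromatic carbon). Going by the values given here, no two measured compounds differ in one place only, so the series gives no direct size for this change.

Compound 2 and compound 3 differ in more than one place and still read alike, while compound 1 goes against that flat picture. In this assay the expected step is a 1.0-fold higher number from compound 2 to compound 4 (0.02 log units; within the scatter), with none beyond the scatter and no firm direction. Compound 4 is estimated at 15000 nM (expected range 7000 nM to 35000 nM).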

Compound 4, half-maximal effective concentration: 24700 nM
Estimate against measurement, compound 4: 1.6-fold (0.22 log units) below; measured number inside the range.
By their numbers in this assay, from the lowest: compound 1; then compounds 3, 2 and 4 (each within the scatter of the next).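

In this assay the series now has its first step at a single place, hydroxymethyl in place of difluoromethoxy on an aromatic carbon, meta to a large group (a 1.7-fold higher number from compound 2 to compound 4 (0.24 log units; within the scatter)). At this position, the two compounds read alike although 4 heavy atoms, including 2 fluorine, leave, 2 heavy atoms enter and 1 hydrogen-bond donor is gained. Nothing at hand bears on the reason for this reading.

On these data alone, whether this position tolerates other groups stays open, since an amine, a carboxylic acid or a longer chain in the same place could still read beyond the scatter from compound 2. Also open, as far as these compounds go, is whether the same exchange reads alike at other places on this ring or with other groups alongside it.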